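Fluoro in Place of Trifluoromethoxy on the Phenyl Ring

This account rests on a few compounds, and the source may have more. Where it says the series, first, only, none or still open, it means among the compounds named here.

Compound 1 `COc1nc2ccc(Br)cc2cc1C(c1ccccc1)n1cc(-c2ccccc2)nn1` gives 30.1% in an ADME assay on PANC-1 cells (Homo sapiens) for cytotoxicity, read by sulforhodamine B assay, with a stated time of 48 h, tested at 10 uM; on this read-out higher numbers stand for more inhibition at the one concentration tested (going by the name of the read-out) and lower numbers for less inhibition. Compound 2 `CCCCCc1cn(C(c2ccccc2)c2cc3cc(Br)ccc3nc2OC)nn1` gives 5.07%. Compound 3 `COc1nc2ccc(Br)cc2cc1C(c1ccccc1)n1cc(-c2ccc(OC(F)(F)F)cc2)nn1` gives 11.7%.

On these three numbers compound 3 stands second highest: its nearest neighbour is compound 2, within the scatter, and its furthest is compound 1, beyond the scatter. Compound 4 `COc1nc2ccc(Br)cc2cc1C(c1ccccc1)n1cc(-c2ccc(F)cc2)nn1` differs from compound 3 in one place: fluoro in place of trifluoromethoxy on an aromatic carbon. Within the data shown here, one measured step bears directly on this position: a number 18.4 percentage points lower from compound 1 to compound 3 (beyond the scatter), where trifluoromethoxy entered in place of hydrogen. The step of a number 6.6 percentage points higher from compound 2 to compound 3 (within the scatter) lies within the scatter and concerns the whole group on the triazole, so it says little here. Since the change from compound 3 to compound 4 removes the trifluoromethoxy again and leaves only fluoro, a partial return toward the number of compound 1 is expected, a modest rise, estimated as a number 8.3 percentage points higher from compound 3 to compound 4 (within the scatter). Compound 4 is therefore expected to give about 20%, with a range from 6% to 34%.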

Compound 4, a percentage reported as inhibition, at one concentration (the size of the read-out at that concentration, not a potency): 14.9%
For compound 4 the middle estimate is 5.1 percentage points above the measured one, and the stated range covers the measured number.
By their numbers in this assay, from the lowest: compounds 2, 3 and 4 (each within the scatter of the next); then compound 1.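

In this assay the move from trifluoromethoxy to fluoro on the phenyl ring gives a number 3.2 percentage points higher from compound 3 to compound 4 (within the scatter) and leaves the two groups indistinguishable at this position. Even the single fluorine, in place of hydrogen, gives a number 15.2 percentage points lower from compound 1 to compound 4 (beyond the scatter) and so a group as large as trifluoromethoxy is not needed for the number to fall below that of the unsubstituted phenyl compound. Replacing pentyl with 4-fluorophenyl gives a number 9.8 percentage points higher from compound 2 to compound 4 (within the scatter) and no measurement at hand explains any of these results.

From the compounds shown here alone, it remains open whether any group on this carbon lowers the number or only the two seen so far do. An amine or a carboxylic acid at the same place could show whether the number stays low or returns toward that of compound 1.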